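A Benzothiazole Urea and the Expected Cytotoxicity

This account rests on a few compounds, and the source may have more. Where it says the series, first, only, none or still open, it means among the compounds named here.

Compound 1 `COc1ccc(NC(=O)NC[C@H]2O[C@H](n3cc(C)c(=O)[nH]c3=O)C[C@@H]2O)cc1` — > 50000 nM
Compound 2 `Cc1cn([C@@H]2C[C@H](O)[C@@H](CNC(=O)Nc3ccccc3COc3ccccc3)O2)c(=O)[nH]c1=O` — > 50000 nM
Compound 3 `Cc1cn([C@@H]2C[C@H](O)[C@@H](CNC(=S)Nc3ccc(OCc4ccccc4)cc3)O2)c(=O)[nH]c1=O` — > 50000 nM

In an ADME assay on MRC5 cells (Homo sapiens) for cytotoxicity (on this read-out lower numbers stand for higher toxicity in this test and higher numbers for lower toxicity in this test), compound 1 gives > 50000 nM, which is a limit of the assay and not a number. Compound 2 likewise gives only a limit, > 50000 nM. Compound 3 also gives a limit, > 50000 nM. All three measured values therefore sit at the limit of > 50000 nM in this assay, at which 3 of the 3 values shown sit, so compound 1 stands where every other measured compound stands, and no order among them can be read from these numbers.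

Compound 4 `Cc1ccc2nc(-c3ccc(NC(=O)NC[C@H]4O[C@H](n5cc(C)c(=O)[nH]c5=O)C[C@@H]4O)cc3)sc2c1` has not yet been measured. Relative to compound 1 the change is 6-methyl-1,3-benzothiazol-2-yl in place of methoxy on an aromatic carbon. Going by the values given here, no step between two measured compounds is available, so the size of this change in this assay cannot be calibrated from within the set; the three measured compounds merely show that this core, with three different aryl ureas or thioureas, stays at the limit.

On that basis the step is expected to be small: an at least 1.1-fold lower number from compound 1 to compound 4 (0.04 log units; that floor lies within the scatter) is the estimate, with a modest shift toward higher toxicity allowed for. Compound 4 is accordingly expected to give about 45000 nM, within a range from 12000 nM to 150000 nM.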

Compound 4, half-maximal cytotoxic concentration: > 50000 nM
Compound 4 gave a limit, no number (the forecaster's own chance of this, stated with the estimate: 55%); middle value at least 1.1-fold (0.04 log units) from the limit.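

In this assay compound 4 gives > 50000 nM as a limit of the assay and not a number. Going by these compounds alone, compound 1 also stands at a limit, so no step from compound 1 to compound 4 can be read. The compounds shown leave open how far any of them lies from that limit, and whether 6-methyl-1,3-benzothiazol-2-yl in place of methoxy changes the read-out at all.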